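A few compounds are considered here, and "the series" means these few. Any claim that something is new, unique, unknown or untested is made for them only; others in the source may bear on it.

Of the compounds shown here, three of one series have been measured in a functional assay on MDA-MB-231 cells (Homo sapiens) for antiproliferative activity, read by MTT assay, with a stated time of 48 h; a lower number here means a stronger inhibitor, a higher number a weaker inhibitor. Compound 3 `NS(=O)(=O)c1ccc(Nc2nccc(Nc3nc4ccc(F)cc4s3)n2)cc1` gives 1800 nM in this assay. Compound 1 `CS(=O)(=O)c1ccc(Nc2nccc(Nc3nc4ccc(F)cc4s3)n2)cc1` differs from compound 3 by methyl in place of amino on a sulfonyl sulfur. In this assay compound 1 gives 2080 nM, the step being a 1.2-fold higher number from compound 3 to compound 1 (0.06 log units; within the scatter). Compound 2 `COc1ccc2nc(Nc3ccnc(Nc4ccc(S(N)(=O)=O)cc4)n3)sc2c1` carries the other core, which differs from that of compound 3 by methoxy in place of fluoro on an aromatic carbon, and compound 2 gives 6240 nM in this assay; the step is a 3.5-fold lower number from compound 2 to compound 3 (0.54 log units; beyond the scatter). Of the three, compound 2 gives the highest number.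

Compound 4 `COc1ccc2nc(Nc3ccnc(Nc4ccc(S(C)(=O)=O)cc4)n3)sc2c1` has not yet been measured. It stands to compound 2 as compound 1 stands to compound 3: the difference is methyl in place of amino on a sulfonyl sulfur, at the same place, a sulfonyl sulfur whose other neighbours are aromatic carbon, so it is the same change that was made once already. Little movement is expected, because a 1.2-fold higher number from compound 3 to compound 1 (0.06 log units; within the scatter) stayed within the scatter on the core of compound 3. Compound 4 is therefore expected to give about 7500 nM in this assay, most likely between 3500 nM and 16000 nM. The expected step is a 1.2-fold higher number from compound 2 to compound 4 (0.08 log units; within the scatter).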

Compound 4, half-maximal inhibitory concentration: 32700 nM
Compound 4: the middle estimate sits 4.4-fold (0.64 log units) below what was measured, and the stated range ends below it.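

In this assay, methyl in place of amino on a sulfonyl sulfur gave a 5.2-fold higher number from compound 2 to compound 4 (0.72 log units; beyond the scatter), so a change that stayed within the scatter on the core of compound 3 did not carry over unchanged to the other core: the same change on two cores in this assay, a 1.2-fold higher number (0.06 log units; within the scatter) from compound 3 to compound 1 and a 5.2-fold higher number (0.72 log units; beyond the scatter) from compound 2 to compound 4, 4.5-fold (0.66 log units) apart, beyond the scatter of two such steps. Read the other way, methoxy in place of fluoro on an aromatic carbon gave a 16-fold higher number from compound 1 to compound 4 (1.20 log units; beyond the scatter), and the size of that change depended on which group stood on the sulfonyl sulfur: the same change on two cores in this assay, a 3.5-fold lower number (0.54 log units; beyond the scatter) from compound 2 to compound 3 and a 16-fold lower number (1.20 log units; beyond the scatter) from compound 4 to compound 1, 4.5-fold (0.66 log units) apart, beyond the scatter of two such steps. The two changes therefore do not add up independently in these four compounds, but this rests on one comparison of two steps and shows neither the reason for the difference nor whether it would recur on any further core.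

The compounds shown leave open whether a chloro or ethoxy group on that aromatic carbon would behave like fluoro or like methoxy. They also leave open how an ethyl group or a dimethylamino group on the sulfonyl sulfur would fare on either core.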